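Hydroxy in Place of Sulfamoyl: An Expected Loss

The source may hold more compounds than are shown below. What is called first, only, known or untested is meant among the compounds shown, and "the series" means these compounds.

Compound 1 `O=[N+]([O-])c1cccc(Nc2nc3ncccc3n2Cc2ccccc2)c1` gives 24200 nM in a functional assay on MCF7 cells (Homo sapiens) for antiproliferative activity, read by MTT assay, with a stated time of 72 h; on this read-out higher numbers stand for weaker inhibition of growth and lower numbers for stronger inhibition of growth. Compound 2 `Cn1nc(-c2ccnc(Nc3ccc(S(N)(=O)=O)cc3)n2)c2ccccc21` gives 940 nM in this assay. Compound 3 `CCn1nc(-c2ccnc(Nc3ccc(S(N)(=O)=O)cc3)n2)c2ccccc21` gives 2280 nM in this assay.

Compound 3 holds the second highest of the three numbers; its nearest neighbour is compound 2, and compound 1 lies furthest from it. Among the measured compounds shown here, the only measured step, a 2.4-fold higher number from compound 2 to compound 3 (0.38 log units; beyond the scatter), concerns the chain on the aromatic nitrogen and says nothing about the group on the other ring. Compound 4 `CCn1nc(-c2ccnc(Nc3ccc(O)cc3)n2)c2ccccc21` differs from compound 3 by hydroxy in place of sulfamoyl on an aromatic carbon. For the measured compounds named here, no measured pair bears directly on this change, so the expectation rests on the step's being an exchange of a larger group for a smaller one at the same position. An upward move, larger than the scatter, is expected, giving a 2.6-fold higher number from compound 3 to compound 4 (0.42 log units; beyond the scatter). Compound 4 is therefore estimated at 6000 nM in this assay, within 1500 nM to 25000 nM.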

Compound 4, concentration for 50% growth inhibition: 5780 nM
The estimate for compound 4 lay 1.0-fold (0.02 log units) above the measured number; the measured number falls inside the stated range.
By their numbers in this assay, from the lowest: compound 2; then compound 3; then compound 4; then compound 1.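

Exchanging sulfamoyl for hydroxy on this aromatic carbon, para to a large group, gave a 2.5-fold higher number from compound 3 to compound 4 (0.40 log units; beyond the scatter) in this assay, the first measured change at this position among the compounds shown. The step is modest, so growth inhibition in this assay does not depend on sulfamoyl alone: compound 4, which carries hydroxy, still gives a measurable number of 5780 nM in this assay. No evidence at hand accounts for the size of this step.

On these data alone, whether an amine or a carboxylic acid on the same aromatic carbon would fall nearer compound 3 or nearer compound 4 remains open. As far as these compounds go, it is also open whether the exchange of sulfamoyl for hydroxy would give a step of similar size with the shorter chain of compound 2 on the aromatic nitrogen.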